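A few compounds are considered here, and "the series" means these few. Any claim that something is new, unique, unknown or untested is made for them only; others in the source may bear on it.

Measured compounds:
compound 1 `CN(C)C(=S)N/N=C/c1cc2cccnc2s1` gives 48400 nM
compound 2 `NC(=S)N/N=C/c1cc2cccnc2s1` gives 6290 nM
compound 3 `NC(=S)N/N=C/c1nc2ccccc2s1` gives 5350 nM

In a functional assay on HeLa cells (Homo sapiens) for antiproliferative activity, read by sulforhodamine B assay, with a stated time of 72 h (on this read-out lower numbers stand for stronger inhibition and higher numbers for weaker inhibition), compound 3 and compound 2 sit within the scatter of each other, so no order between them is claimed. The two share the same atoms joined differently; the difference between the two cores is not broken down here. Compound 1 differs from compound 2 by dimethylamino in place of amino on a thiocarbonyl carbon and this change made a 7.7-fold higher number from compound 2 to compound 1 (0.89 log units; beyond the scatter).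

Compound 4 `CN(C)C(=S)N/N=C/c1nc2ccccc2s1` is not yet measured. It differs from compound 3 by dimethylamino in place of amino on a thiocarbonyl carbon which is the same change, at the same place, as from compound 2 to compound 1. The step is therefore expected to be of similar size, a 7.1-fold higher number from compound 3 to compound 4 (0.85 log units; beyond the scatter), resting on the measured step from compound 2 to compound 1 a 7.7-fold higher number from compound 2 to compound 1 (0.89 log units; beyond the scatter). Compound 4 is thus estimated at 38000 nM, with a range from 12000 nM to 120000 nM.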

Compound 4, half-maximal inhibitory concentration: 2100 nM
Compound 4: middle estimate off by 18-fold (1.26 log units), on the high side; the measured number lies below the stated range.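

In this assay, dimethylamino in place of amino on a thiocarbonyl carbon gives a 2.5-fold lower number from compound 3 to compound 4 (0.41 log units; beyond the scatter), so the step measured on the core of compound 2 does not carry over to the core of compound 3 in either size or direction: the same change on two cores in this assay, a 7.7-fold higher number (0.89 log units; beyond the scatter) from compound 2 to compound 1 and a 2.5-fold lower number (0.41 log units; beyond the scatter) from compound 3 to compound 4, 20-fold (1.29 log units) apart, beyond the scatter of two such steps. For these two pairs, the outcome of the change depends on the core, and a step read on one core is no guide to the other. The pairs do not show which feature of the cores sets this difference, and they say nothing about any other core.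

Open, on these data alone, is how methylamino or a ring amine such as morpholine on the same thiocarbonyl carbon would behave on each core. Such groups could show whether the opposite steps persist beyond dimethylamino.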